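Chain shortening in a hydroxamate series: compounds 1 to 3

The compounds below may be only part of what the source reports. "The series", "measured", "known", "first", "only" and "open" are said of these compounds alone.

compound 1 `Nc1nc2cc(-c3nn(CCCCCCCCCC(=O)NO)c4ncnc(N)c34)ccc2o1` — in a functional assay on Bel-7402 cells (Homo sapiens) for inhibition, read by MTT assay, with a stated time of 72 h (on this read-out lower numbers stand for stronger inhibition and higher numbers for weaker inhibition), compound 1 gives > 50000 nM, a limit of the assay
compound 2 `Nc1nc2cc(-c3nn(CCCCCCCCC(=O)NO)c4ncnc(N)c34)ccc2o1` — in this assay compound 2 gives > 100000 nM, a limit of the assay

Compound 2 stands only at a limit, (the limit of > 100000 nM in this assay, at which 1 of the 2 values shown sits). Within the data shown here, the one further value shown is also a limit, (the limit of > 50000 nM in this assay, at which 1 of the 2 values shown sits). The step that the two limits leave unreadable from compound 1 to compound 2 is therefore not readable. Compound 3 `Nc1nc2cc(-c3nn(CCCCCCC(=O)NO)c4ncnc(N)c34)ccc2o1` differs from compound 2 by hydroxycarbamoyl in place of 2-(hydroxycarbamoyl)ethyl on a saturated chain carbon, six bonds along the chain from an aromatic nitrogen. Among the measured compounds shown here, no measured step bears readably on this change. No step beyond the scatter in this assay is expected, and a limit is again likely. Compound 3 is estimated at 100000 nM, with a range of 30000 nM to 300000 nM. The expected step is a number no higher from compound 2 to compound 3 (the limit leaves the size open).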

Compound 3, half-maximal inhibitory concentration: > 50000 nM
Compound 3: no number, only a limit (the forecaster's own chance of this, stated with the estimate: 80%); the middle value is on the limit's open side.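

Among these compounds, compound 1, compound 2 and compound 3 all stand only at limits in this assay, so no step among them can be read. The compounds shown leave open whether any chain length in this series gives a measurable inhibition value.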